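A few compounds are considered here, and "the series" means these few. Any claim that something is new, unique, unknown or untested is made for them only; others in the source may bear on it.

Compound 1 `COc1cc(NC(C)CCCNC(=O)Nc2cccc(F)c2)c2ncccc2c1` gives 18000 nM
Compound 2 `COc1cc(NC(C)CCCNC(=O)Nc2ccc(Br)cc2)c2ncccc2c1` gives 20000 nM
Compound 3 `COc1cc(NC(C)CCCNC(=O)NNC(=O)Nc2ccc(Br)cc2)c2ncccc2c1` gives 101000 nM

All three values come from a functional assay on HeLa cells (Homo sapiens) for inhibition, read by MTT assay, with a stated time of 72 h (a lower number here means a stronger inhibitor, a higher number a weaker inhibitor), and compound 2 lies second highest, level with compound 1 within the scatter and below compound 3. The next compound is compound 4 (`COc1cc(NC(C)CCCNC(=O)Nc2cccc(O)c2)c2ncccc2c1`), and the change is 3-hydroxyphenyl in place of 4-bromophenyl on an amide-type nitrogen with 3-hydroxyphenyl in place of 4-bromophenyl on an amide-type nitrogen. One swap of aryl groups at this nitrogen is already measured, and a 1.1-fold higher number from compound 1 to compound 2 (0.05 log units; within the scatter) stays small. Only ((4-bromophenyl)carbamoyl)amino moved the number, with a 5.1-fold higher number from compound 2 to compound 3 (0.70 log units; beyond the scatter) and a 5.6-fold higher number from compound 1 to compound 3 (0.75 log units; beyond the scatter) as modest steps, and that is a different kind of change. For the measured compounds named here, no measured compound carries a hydroxyl group. In this assay no step beyond the scatter is therefore expected. The expected step is a 1.3-fold higher number from compound 2 to compound 4 (0.10 log units; within the scatter) as estimated here. Compound 4 is expected at 25000 nM within an estimated range of 10000 nM to 60000 nM in these notes.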

Compound 4, half-maximal inhibitory concentration: 48000 nM
The estimate for compound 4 lay 1.9-fold (0.28 log units) below the measured number, and the stated range covers the measured number.
By their numbers in this assay, from the lowest: compounds 1 and 2 (each within the scatter of the next); then compound 4; then compound 3.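

In this assay the aryl group on the amide-type nitrogen is less indifferent than the earlier pair suggested: a 2.4-fold higher number from compound 2 to compound 4 (0.38 log units; beyond the scatter) and a 2.7-fold higher number from compound 1 to compound 4 (0.43 log units; beyond the scatter) are both beyond the scatter. The 3-hydroxyphenyl compound still keeps clear of the carbamoyl-extended compound, with a 2.1-fold lower number from compound 3 to compound 4 (0.32 log units; beyond the scatter) as the remaining gap. Nothing on hand gives a reason for these steps.

The compounds shown leave open whether 3-aminophenyl or 3-methoxyphenyl on this nitrogen would follow 3-hydroxyphenyl or the halogen-bearing aryl groups.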